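The source may report more compounds than this note shows. Statements on the series, on what has been measured and on what is new or still open speak of the compounds shown alone.

The measured compounds in a toxicity assay on MCF-10A cells (Homo sapiens) for cytotoxicity, read by MTT assay, with a stated time of 48 h; on this read-out lower numbers stand for stronger inhibition and higher numbers for weaker inhibition:
compound 1 `O=C(/C=C/c1ccc2c(c1)B(O)OC2)c1ccc(-c2ccccc2)cc1` gives 20700 nM;
compound 2 `O=C(/C=C/c1ccc2c(c1)B(O)OC2)c1ccc(F)cc1` gives 11800 nM;
compound 3 `CCc1ccc(C(=O)/C=C/c2ccc3c(c2)B(O)OC3)cc1` gives 8800 nM.

Compound 2 stands second highest of the three numbers in this assay; both its neighbours lie within the scatter, compound 3 through a 1.3-fold lower number from compound 2 to compound 3 (0.13 log units; within the scatter) and compound 1 through a 1.8-fold lower number from compound 1 to compound 2 (0.24 log units; within the scatter). Compound 4 `Nc1ccc(C(=O)/C=C/c2ccc3c(c2)B(O)OC3)cc1` carries amino in place of fluoro on an aromatic carbon. Going by the values given here, the steps that bear on this change are the earlier exchanges on the same aromatic carbon: a 1.8-fold lower number from compound 1 to compound 2 (0.24 log units; within the scatter) and a 1.3-fold lower number from compound 2 to compound 3 (0.13 log units; within the scatter), both within the scatter, while a 2.4-fold lower number from compound 1 to compound 3 (0.37 log units; beyond the scatter) is only modest. Exchanging this group has so far moved the number little. Compound 4 is therefore expected to sit close to compound 2 in this assay, with a 1.1-fold lower number from compound 2 to compound 4 (0.03 log units; within the scatter) within the scatter. The estimated value for compound 4 is 11000 nM, with a range from 5000 nM to 25000 nM.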

Compound 4, half-maximal inhibitory concentration: 19900 nM
Compound 4: middle estimate off by 1.8-fold (0.26 log units), on the low side; the range from low to high includes it.
By their numbers in this assay, from the lowest: compounds 3, 2, 4 and 1 (each within the scatter of the next, the first and the last beyond it).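

Amino, which brings a hydrogen-bond donor to this place, leaves the number in this assay within the scatter of both fluoro and phenyl, with a 1.7-fold higher number from compound 2 to compound 4 (0.23 log units; within the scatter) and a 1.0-fold lower number from compound 1 to compound 4 (0.02 log units; within the scatter) as the two steps. Going by these compounds alone, the only step beyond the scatter is the modest 2.3-fold higher number from compound 3 to compound 4 (0.35 log units; beyond the scatter), so ethyl and amino are now the one exchange of this group that separates a further pair. Nothing shown here gives a measured reason for these numbers.

From the compounds shown here alone, whether a carboxylic acid, a methoxy group or a longer chain at this place would move the number further remains open.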